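Carbonyl substituent swap from compound 2 to compound 4

The source may hold more compounds than are shown below. What is called first, only, known or untested is meant among the compounds shown, and "the series" means these compounds.

Measured compounds, all in an assay on isolated protein for inhibition of aldehyde dehydrogenase 1A1 (Homo sapiens), read by spectrophotometry, tested at 10 uM; a higher number here means more inhibition at the concentration tested (going by the name of the read-out), a lower number less inhibition:
compound 1 `Cc1cccc(Cn2c(CN3CCN(C(=O)c4ccc([N+](=O)[O-])cc4)CC3)nc3ccccc32)c1`: 24.3%
compound 2 `Cc1cccc(Cn2c(CN3CCN(C(=O)c4ccc(Cl)cc4)CC3)nc3ccccc32)c1`: 23.2%
compound 3 `CC(C)CCn1c(OC2CCN(C(=O)C3CC3)CC2)nc2ccccc21`: 56.4%

Compound 2 and compound 1 give numbers that lie within the usual scatter of each other, so no order between them can be read. Among the compounds with values here, compound 3, built on a different core, gives a higher number than compound 2, and that gap lies beyond the scatter; no single-point step connects these two, so only the two values themselves are noted.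

Compound 4 `Cc1cccc(Cn2c(CN3CCN(C(=O)c4ccncc4)CC3)nc3ccccc32)c1` is the next compound to be measured. Against compound 2 the change is pyridin-4-yl in place of 4-chlorophenyl on a carbonyl carbon. Within the data shown here, the only measured step on the shared core of compound 1 and compound 2 is a number 1.1 percentage points lower from compound 1 to compound 2 (within the scatter), a change on the same aromatic ring that now leaves altogether. That step did not move the number beyond the scatter. Among the measured compounds shown here, no measured step covers an aromatic ring with a hetero atom entering at this place, so the expectation rests on the single step above and on the closeness of compound 1 and compound 2.

For compound 4 the expected step is a number 1.2 percentage points lower from compound 2 to compound 4 (within the scatter), within the scatter. The estimate for compound 4 in this assay is 22%, range 8% to 38%.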

Compound 4, a percentage reported as inhibition, at one concentration (the size of the read-out at that concentration, not a potency): 20.6%
Estimate against measurement, compound 4: 1.4 percentage points above, and the stated range covers the measured number.
By their numbers in this assay, from the lowest: compounds 4, 2 and 1 (each within the scatter of the next); then compound 3.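

In this assay, the carbonyl carbon on the shared core now carries an aromatic ring with a hetero atom, and this gives a number 2.6 percentage points lower from compound 2 to compound 4 (within the scatter) and a number 3.7 percentage points lower from compound 1 to compound 4 (within the scatter) when the comparison is made with the 4-nitrophenyl ring. The earlier step changed only a substituent on a carbon-only aromatic ring, whereas pyridin-4-yl replaces that ring with one containing nitrogen, and the reading still cannot be separated from either neighbour, so no order among compound 1, compound 2 and compound 4 can be read. Across these three aromatic groups on the carbonyl carbon, the position has so far shown no difference beyond the scatter, and no measurement is available that could explain this result.

Still open, from the compounds shown here alone, is whether this position responds to a group of another kind, such as a carboxylic acid, an amine or a longer chain in place of the aromatic ring on the carbonyl carbon. The compounds shown also leave open whether any change on the rest of the shared core would move the number beyond the scatter.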